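This account rests on a few compounds, and the source may have more. Where it says the series, first, only, none or still open, it means among the compounds named here.

In a physicochemical assay for lipophilicity, read by HPLC (a higher number here means a more lipophilic compound, a lower number a more polar compound), compound 3 `Cc1ccsc1C(=CCCN(C)C(CCO)C(=O)NCc1ccccc1Cl)c1sccc1C` gives 6.23, the highest of the three measured numbers. Compound 1 `Cc1ccsc1C(=CCCN(C)C(CCN)C(=O)NCc1ccc(Cl)cc1)c1sccc1C` gives 5.85 and compound 2 `Cc1ccsc1C(=CCCN(C)C(CCO)C(=O)NCc1ccccc1)c1sccc1C` gives 5.71.

The next compound, compound 4 `Cc1ccsc1C(=CCCN(C)C(CCO)C(=O)NCc1ccc(Cl)cc1)c1sccc1C`, has 4-chlorophenyl in place of 2-chlorophenyl on a saturated chain carbon bound to an amide-type nitrogen. The two compounds have the same atoms, joined differently.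

Among the measured compounds shown here, the one measured step that bears on this change is a number 0.52 log units higher from compound 2 to compound 3 (beyond the scatter), where chloro replaces hydrogen on an aromatic carbon. Compound 4 keeps that chlorine, so it should stay close to compound 3. For the measured compounds named here, compound 1 also carries a 4-chlorobenzyl group, but it differs elsewhere too, and no measured pair shows the effect of this change alone.

The expected step in this assay is a number 0.03 log units lower from compound 3 to compound 4 (within the scatter), an estimate that stays within the usual scatter. For compound 4 the estimated value is 6.2, with an expected range of 5.9 to 6.5.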

Compound 4, partition coefficient: 6.38
For compound 4 the middle estimate is 0.18 log units below the measured one, within the range that was stated.
By their numbers in this assay, from the lowest: compounds 2 and 1 (each within the scatter of the next); then compounds 3 and 4 (each within the scatter of the next).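

Compound 4 shows that the place of the chlorine on the benzyl group makes no clear difference in this assay: there is a number 0.15 log units higher from compound 3 to compound 4 (within the scatter), so 2-chlorophenyl and 4-chlorophenyl cannot be told apart here. The step seen on adding chloro in place of hydrogen also appears with 4-chlorophenyl, with a number 0.67 log units higher from compound 2 to compound 4 (beyond the scatter), alongside a number 0.52 log units higher from compound 2 to compound 3 (beyond the scatter) for 2-chlorophenyl. Compound 4 also isolates hydroxy in place of amino with the 4-chlorobenzyl group kept, giving a number 0.53 log units higher from compound 1 to compound 4 (beyond the scatter).

No measurement here explains why any of these steps occur. As far as these compounds go, how a methoxy group or a nitrile in place of the chlorine, or a carboxylic acid in place of the hydroxy, would read in this assay remains open.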